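Benzothiophene trimethoxybenzoyl series: arylamino variant at the ring carbon

The source may report more compounds than this note shows. Statements on the series, on what has been measured and on what is new or still open speak of the compounds shown alone.

Measured so far:
compound 1 `COc1cc(C(=O)c2sc3ccccc3c2-c2ccc(C)cc2)cc(OC)c1OC` — 3700 nM
compound 2 `CCOc1ccc(-c2c(C(=O)c3cc(OC)c(OC)c(OC)c3)sc3ccccc23)cc1` — 3000 nM
compound 3 `COc1cc(C(=O)c2sc3ccccc3c2Nc2ccc(C)cc2)cc(OC)c1OC` — 3500 nM

Working notes. In a functional assay on HeLa cells (Homo sapiens) for antiproliferative activity, read by MTT assay, with a stated time of 72 h (a lower number here means a stronger inhibitor, a higher number a weaker inhibitor), compound 1 gives the largest of the three numbers shown, but its gaps to both neighbours sit within the scatter: a 1.2-fold lower number from compound 1 to compound 2 (0.09 log units; within the scatter) and a 1.1-fold lower number from compound 1 to compound 3 (0.02 log units; within the scatter). Compound 2 and compound 3 are likewise indistinguishable, a 1.2-fold higher number from compound 2 to compound 3 (0.07 log units; within the scatter).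

Compound 4 `COc1ccc(Nc2c(C(=O)c3cc(OC)c(OC)c(OC)c3)sc3ccccc23)cc1` differs from compound 1 in one place: (4-methoxyphenyl)amino in place of 4-methylphenyl on an aromatic carbon. For the measured compounds named here, two measured steps bear on it. The step from compound 1 to compound 3 shows that placing the amino link between the core and the aryl group changes nothing beyond the scatter, and the step from compound 1 to compound 2 shows that an alkoxy group in place of the methyl on that aryl ring also changes nothing beyond the scatter. Compound 4 combines both changes, with methoxy rather than ethoxy. No step beyond the scatter is therefore expected in this assay, in either direction.

For compound 4 the estimate is 3300 nM, with a range of 1500 nM to 7500 nM. The expected step is a 1.1-fold lower number from compound 1 to compound 4 (0.05 log units; within the scatter).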

Compound 4, half-maximal inhibitory concentration: 7700 nM
The estimate for compound 4 lay 2.3-fold (0.37 log units) below the measured number; the whole stated range lies below it.
By their numbers in this assay, from the lowest: compounds 2, 3 and 1 (each within the scatter of the next); then compound 4.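

In this assay, the aromatic carbon two ring bonds from the ring sulfur no longer looks indifferent to its substituent: compounds 1, 2 and 3 stay within the scatter of one another, but (4-methoxyphenyl)amino gives a 2.1-fold higher number from compound 1 to compound 4 (0.32 log units; beyond the scatter), a modest loss. With the amino link held constant, methoxy in place of methyl gives a 2.2-fold higher number from compound 3 to compound 4 (0.34 log units; beyond the scatter), so the substituent on the aryl ring matters with this link, and (4-methoxyphenyl)amino in place of 4-ethoxyphenyl gives a 2.6-fold higher number from compound 2 to compound 4 (0.41 log units; beyond the scatter). Nothing available accounts for these steps.

Still open, from the compounds shown here alone, is whether the loss is specific to methoxy on the amino-linked ring or extends to ethoxy, hydroxy or chloro there. Going by these compounds, the role of the amine hydrogen is also open, and an N-methylamino link would test it.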